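The source may hold more compounds than are shown below. What is called first, only, known or untested is meant among the compounds shown, and "the series" means these compounds.

Compounds measured so far:
compound 1 `O=C(O)Cn1c(SCCOc2ccc3ccccc3c2)nc2ccccc21`, 2500 nM
compound 2 `O=C(O)Cn1c(SCCCNc2ccccc2)nc2ccccc21`, 2690 nM
compound 3 `COc1cccc(CSc2nc3ccccc3n2CC(=O)O)c1`, 72 nM

In an assay on HEK293 cells for displacement of a labelled ligand from prostaglandin D2 receptor 2 (Homo sapiens) (a lower number here means a stronger inhibitor, a higher number a weaker inhibitor), compound 3 has the lowest number of the three, and both compound 1 and compound 2 lie well beyond the scatter above it. Compound 4 `COC(=O)c1cccc(CSc2nc3ccccc3n2CC(=O)O)c1` differs from compound 3 in one place: methoxycarbonyl in place of methoxy on an aromatic carbon. Within the data shown here, no measured pair in this set shows the effect of such an exchange, so there is nothing to anchor a direction. A step of modest size, if any, is expected, more likely toward a somewhat higher number, as a 2.1-fold higher number from compound 3 to compound 4 (0.32 log units; beyond the scatter) expresses. On that basis compound 4 is estimated at 150 nM in this assay, with a plausible range from 40 nM to 600 nM.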

Compound 4, half-maximal inhibitory concentration: 450 nM
Compound 4: middle estimate off by 3.0-fold (0.48 log units), on the low side; the measured number falls inside the stated range.
By their numbers in this assay, from the lowest: compound 3; then compound 4; then compounds 1 and 2 (each within the scatter of the next).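

In this assay, methoxycarbonyl in place of methoxy on this aromatic carbon, meta to a large group, gives a 6.3-fold higher number from compound 3 to compound 4 (0.80 log units; beyond the scatter). Among these compounds, this is the first comparison in the set that changes one place only, and it shows that the number at this position responds to the exchange, with the step lying beyond the scatter. Nothing available here bears on the reason for this step.

On these data alone, whether a carboxylic acid, an amine or a plain hydrogen on this carbon would raise the number as well remains open. So does whether methoxycarbonyl would give a similar step on another carbon of this ring.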